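Amine substituent swap carried from one linker to another

This account rests on a few compounds, and the source may have more. Where it says the series, first, only, none or still open, it means among the compounds named here.

Measured in a functional assay on cells for antagonist activity at C-X-C chemokine receptor type 4 (Homo sapiens), read by fluorescence and calcium flux, with stated times of 25 min and 90 s; a higher number here means a weaker inhibitor, a lower number a stronger inhibitor:
compound 1 `CC1(C)CCC(NCc2ccc(CN(C[C@H]3Cc4ccccc4CN3)[C@H]3CCCc4cccnc43)cc2)CC1`: 661 nM
compound 2 `c1ccc(CNCc2ccc(CN(C[C@H]3Cc4ccccc4CN3)[C@H]3CCCc4cccnc43)cc2)nc1`: 286 nM
compound 3 `CC1(C)CCC(NC/C=C/CN(C[C@H]2Cc3ccccc3CN2)[C@H]2CCCc3cccnc32)CC1`: 64.6 nM

Compound 1 and compound 2 share a core and differ only by (pyridin-2-yl)methyl in place of 4,4-dimethylcyclohexyl on an amine nitrogen. That change gave a 2.3-fold lower number from compound 1 to compound 2 (0.36 log units; beyond the scatter). Compound 3 carries a different core; the difference between the core of compound 3 and the core of compound 1 is not broken down here. Among the three measured, compound 3 has the lowest number, and its gap to compound 2 as well as to compound 1 lies beyond the scatter.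

Compound 4 `C(=C/CN(C[C@H]1Cc2ccccc2CN1)[C@H]1CCCc2cccnc21)\CNCc1ccccn1` is not yet measured. It differs from compound 3 by (pyridin-2-yl)methyl in place of 4,4-dimethylcyclohexyl on an amine nitrogen, the same change, at the same kind of place, as from compound 1 to compound 2. Going by the values given here, the step of a 2.3-fold lower number from compound 3 to compound 4 (0.36 log units; beyond the scatter) is expected to be of about the same size as the earlier one, because a 2.3-fold lower number from compound 1 to compound 2 (0.36 log units; beyond the scatter) is the only precedent for this change, and it rests on that single pair. Compound 4 is therefore estimated at 28 nM in this assay, within 12 nM to 80 nM.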

Compound 4, half-maximal inhibitory concentration in the C-X-C chemokine receptor type 4 assay: 58.3 nM
Compound 4: the middle estimate sits 2.1-fold (0.32 log units) below what was measured, and the stated range covers the measured number.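

In the C-X-C chemokine receptor type 4 assay, replacing 4,4-dimethylcyclohexyl with (pyridin-2-yl)methyl on the amine nitrogen gave a 1.1-fold lower number from compound 3 to compound 4 (0.04 log units; within the scatter) on the core of compound 3, so the two groups cannot be told apart on that core. Set beside the step on the core of compound 1, the result does not show that the core changes the effect of the swap: the same change on two cores in the C-X-C chemokine receptor type 4 assay, a 2.3-fold lower number (0.36 log units; beyond the scatter) from compound 1 to compound 2 and a 1.1-fold lower number (0.04 log units; within the scatter) from compound 3 to compound 4, 2.1-fold (0.32 log units) apart, within the scatter of two such steps. Going by these compounds alone, with only two pairs, this shows agreement within the scatter and no more: it neither establishes a constant step for this change across cores nor shows that the step on the first core would recur on a third.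

In a physicochemical assay for permeability, using PAMPA, with a stated time of 4 h, at pH 5.5, tested at 100 uM (on this read-out higher numbers stand for higher permeability and lower numbers for lower permeability), compound 4 gives 18 nm/s as a single value, and for compound 3 the entry reads "not determined" (no result reported), so the effect of the change on that read-out cannot be read. Still open, on these data alone, is how a plain benzyl group or a (pyridin-3-yl)methyl group on the same amine nitrogen would behave on either core, which would show whether the pyridine nitrogen matters.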